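The source may report more compounds than this note shows. Statements on the series, on what has been measured and on what is new or still open speak of the compounds shown alone.

Of the compounds shown here, three have been measured in a physicochemical assay for lipophilicity, measured as octanol-water partition; on this read-out higher numbers stand for higher lipophilicity and lower numbers for lower lipophilicity. Compound 1 `COc1cc(/C=N/NC(=O)COc2cccc3ccccc23)cc(OC)c1OC` gives 3.26, compound 2 `O=C(COc1cccc2ccccc12)N/N=C/c1c(O)ccc2ccccc12` gives 4.74, and compound 3 `O=C(COc1cccc2ccccc12)N/N=C/c1ccc(O)cc1` gives 3.73. Compound 3 therefore stands second highest of the three numbers: compound 1 lies lower, beyond the scatter, and compound 2 lies higher, again beyond the scatter. Compound 4 `O=C(COc1cccc2ccccc12)N/N=C/c1ccccc1Br` has not yet been measured. It differs from compound 3 in one place: 2-bromophenyl in place of 4-hydroxyphenyl on a carbon with a double bond to nitrogen. Among the measured compounds shown here, no pair of measured compounds differs in just one place, so no measured step is available as a guide. Compound 4 is expected to come out higher than compound 3 by a step well beyond the scatter, estimated as a number 1.37 log units higher from compound 3 to compound 4 (beyond the scatter). Compound 4 is estimated at 5.1, with a likely range from 4.6 to 5.6.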

Compound 4, partition coefficient: 4.81
Estimate against measurement, compound 4: 0.29 log units above, within the range that was stated.
By their numbers in this assay, from the lowest: compound 1; then compound 3; then compounds 2 and 4 (each within the scatter of the next).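

Among the compounds shown here, at the carbon with a double bond to nitrogen, putting 2-bromophenyl in place of 4-hydroxyphenyl gives the first single-place step in this assay, a number 1.08 log units higher from compound 3 to compound 4 (beyond the scatter). The read-out thus changes strongly at this position, although the heavy-atom count stays the same and the entering group has no hydrogen-bond donor or acceptor. Nothing available here explains the size of this step.

On these data alone, whether the step follows the loss of the hydroxyl or the arrival of the bromine remains open. A plain phenyl or an aminophenyl at this position could begin to separate the two.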